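The Same Added Group on Two Cores

The source may hold more compounds than are shown below. What is called first, only, known or untested is meant among the compounds shown, and "the series" means these compounds.

Measured compounds:
compound 1, `Cc1ccccc1Cc1ccc(N2CCC[C@H]2CC(=O)O)cc1`, a limit of > 33000 nM in a functional assay on cells for agonist activity at Free fatty acid receptor 1 (Mus musculus), read by FLIPR and calcium flux, with a stated time of 100 s; on this read-out lower numbers stand for an effect already at smaller amounts and higher numbers for an effect only at larger amounts of compound
compound 2, `Cc1ccccc1Oc1ccc(N2CCC[C@H]2CC(=O)O)cc1`, 5600 nM in this assay
compound 3, `COc1ccc(F)c(-c2cccc(Oc3ccc(N4CCC[C@H]4CC(=O)O)cc3)c2C)c1`, 3000 nM in this assay

Compound 1 and compound 2 are the two cores of this set; the difference between the two cores is not broken down here. In this assay compound 1 gives only a limit, > 33000 nM, and no number. Compound 2 gives 5600 nM in the same measurement. The change from compound 2 to compound 3 is 2-fluoro-5-methoxyphenyl in place of hydrogen on an aromatic carbon; it made a 1.9-fold lower number from compound 2 to compound 3 (0.27 log units; within the scatter), so the two values cannot be told apart. The unmeasured compound 4, `COc1ccc(F)c(-c2ccc(Cc3ccc(N4CCC[C@H]4CC(=O)O)cc3)c(C)c2)c1`, carries the same kind of change on the core of compound 1: 2-fluoro-5-methoxyphenyl in place of hydrogen on an aromatic carbon. The surroundings of the place differ: in compound 3 the new group sits ortho to a methyl group and meta to a large group, whereas in compound 4 it sits meta to a methyl group and para to a large group. Because compound 1 sits at the limit of > 33000 nM in this assay, at which 1 of the 3 values shown sits, the starting point is itself known only as a limit. The expected step is a step that the limit leaves unreadable from compound 1 to compound 4, set beside the earlier one, and it rests on that step between the measured pair being within the scatter. Compound 4 is therefore expected to give about 40000 nM, in a wide band from 10000 nM to 200000 nM, and a limit rather than a number is quite possible.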

Compound 4, half-maximal effective concentration: 1900 nM
Compound 4: middle estimate off by 21-fold (1.32 log units), on the high side, outside the stated range (below it).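

In this assay the change gave an at least 17-fold lower number from compound 1 to compound 4 (1.23 log units; beyond the scatter) and so a clear gain on the core of compound 1 that has no readable counterpart on the core of compound 2, which means that the step read on one core did not carry over in size to the other: the same change on two cores in this assay, a 1.9-fold lower number (0.27 log units; within the scatter) from compound 2 to compound 3 and an at least 17-fold lower number (1.23 log units; beyond the scatter) from compound 1 to compound 4, at least 9.3-fold (0.96 log units) apart, beyond the scatter of two such steps.
Compound 1 itself is known in this assay only through > 33000 nM as a limit and not a number, so the step on that core has a lower bound and no exact size: the limit of > 33000 nM in this assay, at which 1 of the 4 values shown sits.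
The two cores differ from each other and the new group also stands in different surroundings on them, so this single pair of steps does not show which of these matters, and it gives no rule for other cores in the series.

Going by these compounds, whether a plain phenyl, or a methoxyphenyl without the fluorine, would give a step of the same size on the core of compound 1 stays open. So does whether 2-fluoro-5-methoxyphenyl would still give such a step with an amide in place of the carboxylic acid.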